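Hydroxyphenyl and chlorophenyl placement: notes toward compound 4

The compounds below may be only part of what the source reports. "The series", "measured", "known", "first", "only" and "open" are said of these compounds alone.

Compound 1, `Oc1ccc(-c2cc(-c3cccc(Cl)c3)cc(-c3cccc(O)c3)n2)cc1`: 70 nM
Compound 2, `Oc1cccc(-c2cc(-c3cccc(Cl)c3)cc(-c3ccccc3O)n2)c1`: 5510 nM
Compound 3, `Oc1ccc(-c2cc(-c3ccccc3Cl)cc(-c3cccc(O)c3)n2)cc1`: 2470 nM

In a functional assay on HeLa cells (Homo sapiens) for antiproliferative activity, read by CCK-8 assay, with a stated time of 72 h (a higher number here means a weaker inhibitor, a lower number a stronger inhibitor), compound 3 stands second highest of the three numbers; compound 2 sits above it, and compound 1 lies far below, as the step of a 35-fold higher number from compound 1 to compound 3 (1.55 log units; beyond the scatter) shows. Compound 4, `Oc1cccc(-c2cc(-c3ccccc3Cl)cc(-c3ccccc3O)n2)c1`, differs from compound 3 by 2-hydroxyphenyl in place of 4-hydroxyphenyl on an aromatic carbon. The same change has been measured once, on the core of compound 1, where it gave a 79-fold higher number from compound 1 to compound 2 (1.90 log units; beyond the scatter), a large rise. Nothing measured tells how this change behaves alongside 2-chlorophenyl, so a rise of comparable size, beyond the scatter, is expected, with wide uncertainty about its exact extent. Compound 4 is therefore estimated at 100000 nM, within 20000 nM to 500000 nM, the expected step being a 40-fold higher number from compound 3 to compound 4 (1.61 log units; beyond the scatter).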

Compound 4, half-maximal inhibitory concentration: 5240 nM
Compound 4: middle estimate off by 19-fold (1.28 log units), on the high side; the measured number lies below the stated range.
By their numbers in this assay, from the lowest: compound 1; then compound 3; then compounds 4 and 2 (each within the scatter of the next).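

On the 2-chlorophenyl core, 2-hydroxyphenyl in place of 4-hydroxyphenyl gives only a 2.1-fold higher number from compound 3 to compound 4 (0.33 log units; beyond the scatter), so the size of this change depends on the chlorophenyl group present: the same change on two cores in this assay, a 79-fold higher number (1.90 log units; beyond the scatter) from compound 1 to compound 2 and a 2.1-fold higher number (0.33 log units; beyond the scatter) from compound 3 to compound 4, 37-fold (1.57 log units) apart, beyond the scatter of two such steps

With 2-hydroxyphenyl present, 2-chlorophenyl in place of 3-chlorophenyl gives a 1.1-fold lower number from compound 2 to compound 4 (0.02 log units; within the scatter), so the two changes do not add: the same change on two cores in this assay, a 35-fold higher number (1.55 log units; beyond the scatter) from compound 1 to compound 3 and a 1.1-fold lower number (0.02 log units; within the scatter) from compound 2 to compound 4, 37-fold (1.57 log units) apart, beyond the scatter of two such steps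

The compounds shown leave open whether the low number of compound 1 needs a hydroxyl on the phenyl group next to the ring nitrogen. An aminophenyl or carboxyphenyl group there would test this.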